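The source may hold more compounds than are shown below. What is called first, only, known or untested is meant among the compounds shown, and "the series" means these compounds.

In an ADME assay on RAW264.7 cells (Mus musculus) for cytotoxicity, read by MTT assay, with a stated time of 72 h, tested at 50 uM (on this read-out lower numbers stand for less inhibition and higher numbers for more inhibition at the one concentration tested (going by the name of the read-out)), compound 1 `CCOC(=O)c1sc(-c2ccccn2)nc1N1CCC(NCc2ccc(Cl)cc2Cl)CC1` gives 18.6%, compound 2 `CCOC(=O)c1sc(-c2ccncc2)nc1N1CCC(NCc2ccc(F)cc2)CC1` gives 17.5% and compound 3 `CCOC(=O)c1sc(-c2ccncc2)nc1N1CCC(NCc2cccc(C(F)(F)F)c2)CC1` gives 14.3%; the number for compound 3 sits within the scatter of both compound 1 and compound 2, so the three cannot be told apart. For the measured compounds named here, the one step at the same place, a number 3.2 percentage points lower from compound 2 to compound 3 (within the scatter), also stays within the scatter. Compound 4 `CCOC(=O)c1sc(-c2ccncc2)nc1N1CCC(NCc2ccc(Cl)cc2Cl)CC1` carries 2,4-dichlorophenyl in place of 3-(trifluoromethyl)phenyl on a saturated chain carbon bound to an amine nitrogen. Compound 1 bears the same 2,4-dichlorophenyl on a saturated chain carbon bound to an amine nitrogen, on its own core, and its value in this assay lies within the scatter of compound 3. No step beyond the scatter is therefore expected, the expected step being a number 2.7 percentage points higher from compound 3 to compound 4 (within the scatter). Compound 4 is estimated at 17% in this assay, between 8% and 26%.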

Compound 4, a percentage reported as inhibition, at one concentration (the size of the read-out at that concentration, not a potency): 18.4%
Estimate against measurement, compound 4: 1.4 percentage points below; measured number inside the range.
By their numbers in this assay, from the lowest: compounds 3, 2, 4 and 1 (each within the scatter of the next).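

On a saturated chain carbon bound to an amine nitrogen, 2,4-dichlorophenyl in place of either earlier aryl group leaves this assay within the scatter (a number 4.1 percentage points higher from compound 3 to compound 4 (within the scatter); a number 0.9 percentage points higher from compound 2 to compound 4 (within the scatter)). For the compounds shown here, the first matched change on an aromatic carbon, pyridin-4-yl in place of pyridin-2-yl, also stays within the scatter (a number 0.2 percentage points lower from compound 1 to compound 4 (within the scatter)). No supporting evidence bears on these results. Open, from the compounds shown here alone, is whether a carboxylic acid in place of the ethyl ester, or pyridin-3-yl on that aromatic carbon, would give a step beyond the scatter.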